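From 5-fluoro to 7-fluoro-1-methyl-1H-indol-3-yl in compound 3

The source may report more compounds than this note shows. Statements on the series, on what has been measured and on what is new or still open speak of the compounds shown alone.

Compound 1 `C=CC(=O)Nc1cc(Nc2nccc(-c3cn(C)c4c(F)cccc34)n2)c(OC)cc1N(C)CCN(C)C`: < 100 ug/mL
Compound 2 `C=CC(=O)Nc1cc(Nc2nccc(-c3cn(C)c4ccc(F)cc34)n2)c(OC)cc1N(C)CC[N+](C)(C)[O-]`: < 100 ug/mL

Of the compounds shown here, two have been measured in a physicochemical assay for solubility, in phosphate buffer, at pH 7.4 (a lower number here means a less soluble compound, a higher number a more soluble compound), and neither gave a number. Compound 1 gives < 100 ug/mL, which is a limit of the assay. Compound 2 gives < 100 ug/mL, which is also a limit. Among the measured compounds shown here, the record therefore consists of the limit of < 100 ug/mL in this assay, at which 2 of the 2 values shown sit, and no measured pair offers a step whose size can be read.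

Compound 3 `C=CC(=O)Nc1cc(Nc2nccc(-c3cn(C)c4c(F)cccc34)n2)c(OC)cc1N(C)CC[N+](C)(C)[O-]` has not yet been measured. It carries 7-fluoro-1-methyl-1H-indol-3-yl in place of the 5-fluoro-1-methyl-1H-indol-3-yl of compound 2, on an aromatic carbon of a six-membered aromatic ring with 2 nitrogen: 7-fluoro-1-methyl-1H-indol-3-yl in place of 5-fluoro-1-methyl-1H-indol-3-yl on an aromatic carbon. The two have the same atoms, joined differently.

With only limits to go on, no direction can be favoured in this assay, and no change beyond the scatter is expected. The expected step is a step that the limit leaves unreadable from compound 2 to compound 3. For compound 3 the estimate is 60 ug/mL, with an expected range from 20 ug/mL to 150 ug/mL, and another report as a limit is the likeliest outcome.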

Compound 3, solubility: > 10000 ug/mL
Compound 3: only a limit was reported; the forecaster's own chance of this, stated with the estimate: 80%; at least 160-fold (2.22 log units) between middle value and limit.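

In this assay compound 3 gives > 10000 ug/mL, which is a limit of the assay and not a number. This is the first step at this position whose size can be judged at all: 7-fluoro-1-methyl-1H-indol-3-yl in place of 5-fluoro-1-methyl-1H-indol-3-yl on an aromatic carbon, with the same atoms joined differently, gives an at least 100-fold higher number from compound 2 to compound 3 (2.00 log units; beyond the scatter), so the place of the fluorine on the indolyl group is not a silent detail in this assay: the limit of > 10000 ug/mL in this assay, at which 1 of the 3 values shown sits.

With 7-fluoro-1-methyl-1H-indol-3-yl held fixed, a group of 4 heavy atoms in place of a group of 3 heavy atoms on a saturated chain carbon, two bonds along the chain from a nitrogen on an aromatic ring, gives an at least 100-fold higher number from compound 1 to compound 3 (2.00 log units; beyond the scatter), so the change on the chain counts as well: the limit of < 100 ug/mL in this assay, at which 2 of the 3 values shown sit.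

Both steps run from one limit to another, so their true sizes cannot be read. Going by these compounds, it stays open whether the same jump would follow with a morpholine or a longer chain ending in a primary amine on that side of the molecule, or with chloro in place of the fluoro on the indolyl group.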